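The source may hold more compounds than are shown below. What is called first, only, known or untested is meant among the compounds shown, and "the series" means these compounds.

In a functional assay on A-431 cells (Homo sapiens) for antiproliferative activity (a lower number here means a stronger inhibitor, a higher number a weaker inhibitor), compound 1 `CO[C@@H]1[C@H](OC(=O)NC(=O)CCl)CO[C@]2(COC(C)(C)O2)[C@]1(CCCCCc1ccccc1)OC(=O)NC(=O)CCl` gives 1200 nM, the lower of the two true numbers in this small set. Compound 3 `CCOC(=O)NC(=O)O[C@@H]1CO[C@]2(COC(C)(C)O2)[C@@](O)(C2OC2CC(C)C)[C@@H]1OC` gives 471000 nM, a gap well beyond the scatter. Compound 2 `C=C(C)[C@@]1(O)[C@H](OC)[C@H](OC)CO[C@]12CO2` reads > 500000 nM, which is a limit of the assay and not a number.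

Compound 4 `CO[C@@H]1[C@H](OC(=O)NC(=O)CCl)CO[C@]2(COC(C)(C)O2)[C@@]1(OC(=O)NC(=O)CCl)C1OC1CCCc1ccccc1` differs from compound 1 in one place, with 3-(3-phenylpropyl)oxiran-2-yl in place of 5-phenylpentyl on a saturated ring carbon. Within the data shown here, no pair of measured compounds isolates this exchange, so the expectation for this assay rests on limited ground. Compound 4 keeps both (((chloromethyl)carbonyl)carbamoyl)oxy groups and the rest of the core of compound 1, which gives 1200 nM, so its number is expected to stay close to that value. The expected change is a 1.2-fold lower number from compound 1 to compound 4 (0.08 log units; within the scatter), a step not expected to lie beyond the scatter, although the uncertainty is wide. For compound 4, the estimate is 1000 nM, with an expected range of 250 nM to 5000 nM.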

Compound 4, half-maximal inhibitory concentration: 3700 nM
The estimate for compound 4 lay 3.7-fold (0.57 log units) below the measured number; the range from low to high includes it.
By their numbers in this assay, from the lowest: compound 1; then compound 4; then compound 3. At a limit, above all of these: compound 2.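

In this assay, among these compounds, placing 3-(3-phenylpropyl)oxiran-2-yl instead of 5-phenylpentyl on this saturated ring carbon gives a 3.1-fold higher number from compound 1 to compound 4 (0.49 log units; beyond the scatter), the first step in this set that isolates a single place. The position therefore accepts the chain carrying the three-membered ring with only a modest loss, so the number does not depend strictly on the 5-phenylpentyl group. Nothing shown gives a reason for this step.

The compounds shown do not separate the contribution of the three-membered ring from that of the rest of the exchanged group, and they leave open how a shorter alkyl chain, an amine or a carboxylic acid on this carbon would read. Among the compounds shown here, they also leave open whether both (((chloromethyl)carbonyl)carbamoyl)oxy groups are needed, as no step isolates either one.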